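The source may report more compounds than this note shows. Statements on the series, on what has been measured and on what is new or still open speak of the compounds shown alone.

Measured so far in a physicochemical assay for lipophilicity, in phosphate buffer, measured as octanol-water partition, at pH 11.5; a higher number here means a more lipophilic compound, a lower number a more polar compound:

- compound 1 (`CCCCCCCCNC(=N)NC(=N)Nc1ccc(C)cc1`): 4.93
- compound 2 (`CCCCCCCCNC(=N)NC(=N)Nc1ccc(Cl)cc1`): 5.13

Of these two numbers, the value of compound 2 lies within the scatter of compound 1, so the two cannot be told apart in this assay. The study now turns to compound 3 (`CCCCNC(=N)NC(=N)Nc1ccc(Cl)cc1`), which differs from compound 2 as follows: hydrogen in place of butyl on a saturated chain carbon, four bonds along the chain from an amine nitrogen. This is hydrogen in place of butyl on a saturated chain carbon, four bonds along the chain from an amine nitrogen, and it leaves a butyl chain where compound 2 carries octyl.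

Among the measured compounds shown here, only one measured step is available: a number 0.20 log units higher from compound 1 to compound 2 (within the scatter). For the measured compounds named here, that step is chloro in place of methyl on an aromatic carbon, a change of another kind, and no measured pair differs in its chain. Its size therefore gives no direct guide, and the expectation rests on the structural change alone: a clearly lower number, well beyond the scatter. The expected step is a number 1.93 log units lower from compound 2 to compound 3 (beyond the scatter). The estimated value for compound 3 is 3.2, with an expected range from 2.6 to 3.8.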

Compound 3, partition coefficient: 3.13
The estimate for compound 3 lay 0.07 log units above the measured number; low and high end bracket the measured number.
By their numbers in this assay, from the lowest: compound 3; then compounds 1 and 2 (each within the scatter of the next).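

Among the compounds shown here, the chain on the amine nitrogen is the first place where a single change moves the number in this assay beyond the scatter: shortening octyl to butyl gives a number 2.00 log units lower from compound 2 to compound 3 (beyond the scatter), a large step. The earlier change, chloro in place of methyl on an aromatic carbon, gave only a number 0.20 log units higher from compound 1 to compound 2 (within the scatter), which lies within the scatter, so among the compounds shown the chain carries far more weight in this assay than that aromatic substituent. Nothing measured here explains the size of the chain step, and no supporting data on its cause are available.

Two chain lengths do not define a trend, so the compounds shown leave open whether a hexyl chain would fall about midway between compound 3 and compound 2, and whether a longer chain such as decyl would raise the number further or level off. As far as these compounds go, it also remains open whether the same shortening would give a step of similar size with methyl rather than chloro on the aromatic carbon, or with a more different group there, such as a methoxy group or a carboxylic acid.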